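Hydrazide series: from compound 2 to compound 4

The source may hold more compounds than are shown below. What is called first, only, known or untested is meant among the compounds shown, and "the series" means these compounds.

Compound 1 `O=C(NNc1ccccc1F)c1ccccc1NS(=O)(=O)c1cnc(O)nc1O` gives 9610 nM
Compound 2 `O=C(NNc1ccc(F)cc1)c1ccccc1NS(=O)(=O)c1cnc(O)nc1O` gives > 20000 nM
Compound 3 `CCCCOc1ccc(C(=O)NNC(=O)c2ccc(NS(=O)(=O)c3cnc(O)nc3O)cc2)cc1` gives 9010 nM

All three readings come from a functional assay on A549 cells (Homo sapiens) for antiproliferative activity, read by MTT assay, with a stated time of 24 h (a lower number here means a stronger inhibitor, a higher number a weaker inhibitor), and no other assay is at hand. Compound 2 reads > 20000 nM as a limit and not as a number. Among the compounds with values here, compound 2 is thus the one compound at the limit of > 20000 nM in this assay, at which 1 of the 3 values shown sits, in this small set.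

The next structure is compound 4 `O=C(NNC(=O)c1ccccc1NS(=O)(=O)c1cnc(O)nc1O)c1cccc(Cl)c1` with (3-chlorophenyl)carbonyl in place of 4-fluorophenyl on an amine nitrogen. The counted difference (3-chlorophenyl)carbonyl in place of 4-fluorophenyl on an amine nitrogen also reads as (4-fluorophenyl)amino to ((3-chlorophenyl)carbonyl)amino.

Within the data shown here, the only measured step at this place is an at least 2.0-fold higher number from compound 1 to compound 2 (0.31 log units; beyond the scatter) and it exchanges one fluorophenyl for another, so it shows that the number can move with a change here but gives no size for a carbonyl-linked ring. Compound 3 also carries a carbonyl on that nitrogen and gives 9010 nM as a true number, though it differs from compound 4 in more than one place.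

On that basis a modest move toward a lower number in this assay is expected, and compound 4 may still end at a limit. The expected move is an at least 1.5-fold lower number from compound 2 to compound 4 (0.18 log units; that floor lies within the scatter) on this estimate. For compound 4 the estimated value is 13000 nM within an expected range of 6000 nM to 28000 nM at this stage.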

Compound 4, half-maximal inhibitory concentration: 1260 nM
Beside the measured number, compound 4's estimate is 10-fold (1.01 log units) above it; the measured number lies below the stated range.
By their numbers in this assay, from the lowest: compound 4; then compounds 3 and 1 (each within the scatter of the next). At a limit, above all of these: compound 2.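

In this assay, the amine nitrogen whose other neighbour is the amide-type nitrogen responds strongly when a fluorophenyl group gives way to (3-chlorophenyl)carbonyl: the change gives an at least 15-fold lower number from compound 2 to compound 4 (1.20 log units; beyond the scatter), and against the other fluorophenyl it gives a 7.6-fold lower number from compound 1 to compound 4 (0.88 log units; beyond the scatter). Until now, this position had shown only a rise in the number, in an at least 2.0-fold higher number from compound 1 to compound 2 (0.31 log units; beyond the scatter), whereas these two steps show that a change here can also lower it well beyond the scatter. The first of the two new steps gives only a floor because the value of compound 2 is a limit: the limit of > 20000 nM in this assay, at which 1 of the 4 values shown sits.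

The change brings in the carbonyl and the chlorine together, so the compounds shown do not separate what each contributes to the lower number. From the compounds shown here alone, it remains open whether a plain phenylcarbonyl group with no chlorine, or an acetyl group with no ring at all, on the same nitrogen would keep the number of compound 4, and a direct pair of that kind would be needed to assign the step to one part of the group.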